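Cyclohexyl in place of methylsulfanyl: notes on compound 3

A few compounds are considered here, and "the series" means these few. Any claim that something is new, unique, unknown or untested is made for them only; others in the source may bear on it.

Measured so far in a functional assay on cells (Homo sapiens), read by thymidine incorporation; a lower number here means a stronger inhibitor, a higher number a weaker inhibitor
- compound 1 (`CNc1cc(NCc2cccnc2)n2ncc(Br)c2n1`): 1200 nM
- compound 2 (`CSc1cc(NCc2cccnc2)n2ncc(Br)c2n1`): 990 nM

Among the measured compounds shown here, compound 2 cannot be separated from compound 1, since the only measured step is a 1.2-fold lower number from compound 1 to compound 2 (0.08 log units; within the scatter) and no other values are available. Compound 3 (`Brc1cnn2c(NCc3cccnc3)cc(C3CCCCC3)nc12`) carries cyclohexyl in place of methylsulfanyl on an aromatic carbon. The same carbon changed in the measured step, which exchanged methylamino for methylsulfanyl and gave a 1.2-fold lower number from compound 1 to compound 2 (0.08 log units; within the scatter) as its result. For the measured compounds named here, that step is a weak guide, as no compound with a ring at this carbon has been measured. A modest shift toward a lower number is expected, with the direction uncertain. The expected change in this assay is a 1.7-fold lower number from compound 2 to compound 3 (0.22 log units; within the scatter) (an estimate only). The estimated value for compound 3 is 600 nM (expected range 120 nM to 3000 nM).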

Compound 3, half-maximal inhibitory concentration: 200 nM
Compound 3: the middle estimate sits 3.0-fold (0.48 log units) above what was measured; low and high end bracket the measured number.
By their numbers in this assay, from the lowest: compound 3; then compounds 2 and 1 (each within the scatter of the next).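

At this aromatic carbon, this assay now separates the substituents: cyclohexyl in place of methylsulfanyl gives a 5.0-fold lower number from compound 2 to compound 3 (0.69 log units; beyond the scatter), and cyclohexyl in place of methylamino gives a 6.0-fold lower number from compound 1 to compound 3 (0.78 log units; beyond the scatter), whereas the exchange of methylamino for methylsulfanyl stayed within the scatter. Among the compounds shown here, the position is therefore not indifferent to what it carries, and cyclohexyl, the only group here with a ring and with carbon alone, is the first change at this carbon to move the number beyond the scatter. Nothing available on these compounds accounts for the gain.

On these data alone, whether the step follows from the ring itself or from the greater number of heavy atoms stays open, and an open chain such as n-hexyl or a phenyl ring at this carbon would help separate the two. Also open, as far as these compounds go, is whether a piperidine ring or a cyclohexyl ring bearing a hydroxyl group would keep the lower number.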